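Predicting a methoxyphenyl amide in the nicotinic binding assay

This account rests on a few compounds, and the source may have more. Where it says the series, first, only, none or still open, it means among the compounds named here.

Three amides built on the same core have been measured in a binding assay on membranes from Cerebral cortex for displacement of a labelled ligand from Neuronal acetylcholine receptor; alpha4/beta2 (Rattus norvegicus); a higher number here means a weaker inhibitor, a lower number a stronger inhibitor. Compound 1 `COc1cc(NC(=O)c2cncc(N3CC4CC(C3)N4)c2)cc(OC)c1` gives 0.985 nM. Compound 2 `O=C(Nc1ccccc1F)c1cncc(N2CC3CC(C2)N3)c1` gives 0.315 nM. Compound 3 `O=C(NCc1ccccc1)c1cncc(N2CC3CC(C2)N3)c1` gives 1.8 nM, the highest of the three numbers: compound 1 lies within the scatter of it, while compound 2 lies beyond the scatter, as the step of a 5.7-fold higher number from compound 2 to compound 3 (0.76 log units; beyond the scatter) shows.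

Compound 4 `COc1cccc(NC(=O)c2cncc(N3CC4CC(C3)N4)c2)c1` has not yet been measured. Compared with compound 3, the change is 3-methoxyphenyl in place of benzyl on an amide-type nitrogen. This is the reverse of the kind of move seen between compound 2 and compound 3, where replacing a ring set on the amide-type nitrogen by benzyl raised the number; compound 1, which also carries a ring on the amide-type nitrogen, shows a number within the scatter of compound 3 but lower than it.

On that basis, putting a ring back on the amide-type nitrogen in compound 4 is expected to move the number down, roughly by the step of a 3.6-fold lower number from compound 3 to compound 4 (0.56 log units; beyond the scatter). Compound 4 is therefore estimated at 0.5 nM in this assay, with a likely range from 0.2 nM to 1.5 nM.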

Compound 4, inhibition constant: 0.56 nM
Estimate against measurement, compound 4: 1.1-fold (0.05 log units) below; low and high end bracket the measured number.
By their numbers in this assay, from the lowest: compounds 2, 4, 1 and 3 (each within the scatter of the next, the first and the last beyond it).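

In this assay, 3-methoxyphenyl in place of benzyl on the amide-type nitrogen gives a 3.2-fold lower number from compound 3 to compound 4 (0.51 log units; beyond the scatter), so a second ring group, besides the 2-fluorophenyl of compound 2, now stands on the low side of benzyl, and the earlier gap was not unique to that one group; compound 1 goes against this pattern, since its number lies within the scatter of that of compound 3. Exchanging the 2-fluorophenyl for 3-methoxyphenyl gives a 1.8-fold higher number from compound 2 to compound 4 (0.25 log units; within the scatter), so this assay does not separate these two groups at this position. Hydrogen in place of a methoxy on an aromatic carbon gives a 1.8-fold lower number from compound 1 to compound 4 (0.25 log units; within the scatter), so the extra methoxy of compound 1 makes no readable difference to compound 4.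

Nothing available explains why these ring groups and benzyl differ at this nitrogen. The compounds shown leave open how an amine or a carboxylic acid on the aromatic ring would fare, and whether a longer chain than benzyl, such as 2-phenylethyl, on the amide-type nitrogen would push the number further up.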